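Methylation of a phenol on two related cores

A few compounds are considered here, and "the series" means these few. Any claim that something is new, unique, unknown or untested is made for them only; others in the source may bear on it.

The measured compounds:
- compound 1, `COc1cc2c(c(O)c1OC)c(=O)ccn2C`: in a functional assay on L1210 cells (Mus musculus) for antiproliferative activity (a lower number here means a stronger inhibitor, a higher number a weaker inhibitor), compound 1 gives > 40000 nM, a limit of the assay.
- compound 2, `COc1cc2c(c(OC)c1OC)c(=O)ccn2C`: in this assay compound 2 gives > 40000 nM, a limit of the assay.
- compound 3, `Cc1ccc(O)c2c(O)ccnc12`: in this assay compound 3 gives > 40000 nM, a limit of the assay.

From compound 1 to compound 2 the change is methyl in place of hydrogen on an oxygen on an aromatic ring. The step that the two limits leave unreadable from compound 1 to compound 2 cannot be sized, because of the limit of > 40000 nM in this assay, at which 3 of the 3 values shown sit. The difference between the core of compound 1 and the core of compound 3 is not broken down here. Compound 4, `COc1ccc(C)c2nccc(O)c12`, is not yet measured; from compound 3 to compound 4 the change is methyl in place of hydrogen on an oxygen on an aromatic ring, the same change as that from compound 1 to compound 2, at a place described in the same words.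

Going by the values given here, since compound 3 sits at a limit and the only measured instance of this change led from one limit to another, compound 4 is expected to give 60000 nM in this assay, within 20000 nM to 200000 nM, most likely reported again as a limit. The step this estimate implies is expected to be a step that the limit leaves unreadable from compound 3 to compound 4.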

Compound 4, half-maximal inhibitory concentration: > 40000 nM
Compound 4: only a limit was reported (the forecaster's own chance of this, stated with the estimate: 85%); the middle value is on the limit's open side.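

No size can be given to the step from compound 3 to compound 4, because both values are limits of the assay: the limit of > 40000 nM in this assay, at which 4 of the 4 values shown sit.

The compounds shown leave open how strongly any of them acts in this assay, and whether methyl in place of hydrogen on an oxygen on an aromatic ring changes that on either core.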